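A methyl-to-fluoro swap on compound 2

The source may report more compounds than this note shows. Statements on the series, on what has been measured and on what is new or still open speak of the compounds shown alone.

Among the compounds with values here, only two compounds have been measured so far, and both were tested in a functional assay on SMMC-7721 cells (Homo sapiens) for cytotoxicity, read by MTT assay, with a stated time of 24 h; on this read-out lower numbers stand for stronger inhibition and higher numbers for weaker inhibition. There, compound 1 `COc1ccc(/C=C2\CN(C)C/C(=C\c3ccncc3)C2=O)c(OC)c1OC` gives 9080 nM, and compound 2 `Cc1ccc(S(=O)(=O)N2C/C(=C\c3cccnc3)C(=O)/C(=C/c3ccccc3F)C2)cc1` gives 10300 nM. These values lie within the usual scatter of repeated measurements, so compound 2 stands level with compound 1 and neither can be ranked as the better inhibitor.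

Compound 3 `O=C1/C(=C/c2cccnc2)CN(S(=O)(=O)c2ccc(F)cc2)C/C1=C\c1ccccc1F` has not yet been measured. It differs from compound 2 in one place: fluoro in place of methyl on an aromatic carbon. In other words, fluoro takes the place of methyl on an aromatic carbon, para to a large group, turning (4-methylphenyl)sulfonyl into (4-fluorophenyl)sulfonyl.

Within the data shown here, no measured pair of compounds shows this change, so the data offer no direct guide to its effect. Among the measured compounds shown here, the only anchor is compound 2 at 10300 nM. With no evidence for a larger shift, the expected step is a 1.1-fold lower number from compound 2 to compound 3 (0.06 log units; within the scatter), which would be no change beyond the scatter. The estimated value for compound 3 is 9000 nM, with an expected range of 4000 nM to 20000 nM.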

Compound 3, half-maximal inhibitory concentration: 9900 nM
Compound 3: the middle estimate sits 1.1-fold (0.04 log units) below what was measured; the measured number falls inside the stated range.
By their numbers in this assay, from the lowest: compounds 1, 3 and 2 (each within the scatter of the next).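

Within the data shown here, this is the first direct comparison at this position. Compound 1 could not provide one, as it differs from compound 2 in more than one place.

Among these compounds, this is the first direct comparison at this position. Compound 1 differs from compound 2 in more than one place. In this assay putting fluoro in place of methyl on the aromatic carbon, para to a large group, gives a 1.0-fold lower number from compound 2 to compound 3 (0.02 log units; within the scatter) so (4-fluorophenyl)sulfonyl and (4-methylphenyl)sulfonyl stand level here, and this single swap gives no measurable separation between the two compounds. Nothing shown here explains this result, and the single pair cannot say whether the two groups act alike or whether the read-out simply does not respond to changes at this spot.

The compounds shown leave open whether a group of a different kind at this position, such as an amine, a carboxylic acid or a longer chain like butyl, would shift the number beyond the scatter. Among the compounds shown here, they also leave open whether the same swap from methyl to fluoro would read the same way on a different core, since this pair is the only example of it.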